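Methyl on the ring amine of compound 1

A few compounds are considered here, and "the series" means these few. Any claim that something is new, unique, unknown or untested is made for them only; others in the source may bear on it.

Among the measured compounds shown here, in an ADME assay on HOS cells (Homo sapiens) for cytotoxicity (a lower number here means that less compound is tolerated, a higher number that more compound is tolerated), compound 1 `CN(Cc1nc2ccccc2n1CC1CCNC1)C1CCCc2cccnc21` gives 7700 nM, the higher of the two values measured so far, while compound 2 `CN1CCC[C@H](Cn2c(CN(C)[C@H]3CCCc4cccnc43)nc3ccccc32)C1` gives 3600 nM. Compound 3 `CN1CCC(Cn2c(CN(C)C3CCCc4cccnc43)nc3ccccc32)C1` differs from compound 1 by methyl in place of hydrogen on an amine nitrogen in a ring, turning pyrrolidin-3-yl into 1-methylpyrrolidin-3-yl (methyl in place of hydrogen on an amine nitrogen in a ring). For the measured compounds named here, no measured pair isolates this change. Compound 2, also methylated on a ring amine nitrogen, stands at 3600 nM, so a small fall, near the scatter, is expected. The expected change is a 1.5-fold lower number from compound 1 to compound 3 (0.19 log units; within the scatter). The estimate for compound 3 is 5000 nM, with an expected range of 2500 nM to 10000 nM.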

Compound 3, half-maximal cytotoxic concentration: 15000 nM
Beside the measured number, compound 3's estimate is 3.0-fold (0.48 log units) below it; measured number outside the range, above it.
By their numbers in this assay, from the lowest: compound 2; then compounds 1 and 3 (each within the scatter of the next).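

In this assay, among the compounds shown here, the first isolated reading of methyl in place of hydrogen on this amine nitrogen in a ring is a 1.9-fold higher number from compound 1 to compound 3 (0.29 log units; within the scatter). The earlier compounds shown here offered no single-change step, and this one shows that turning pyrrolidin-3-yl into 1-methylpyrrolidin-3-yl leaves the number within the scatter. No measured evidence accounts for the result. From the compounds shown here alone, it remains open whether an ethyl, an acetyl or a longer chain on this nitrogen would also stay within the scatter of compound 1.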